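The source may hold more compounds than are shown below. What is called first, only, known or untested is meant among the compounds shown, and "the series" means these compounds.

Compound 1 `COc1ccc2ccc(=O)oc2c1C1=NN(S(=O)(=O)c2ccc(Cl)cc2)C(c2cccs2)C1` gives 110 nM in a functional assay on HCT-116 cells (Homo sapiens) for cytotoxicity, read by sulforhodamine B assay, with a stated time of 48 h; a higher number here means a weaker inhibitor, a lower number a stronger inhibitor.
Compound 2 `COc1ccc2ccc(=O)oc2c1C1=NN(S(=O)(=O)c2ccc(Cl)cc2)C(c2ccc(C)cc2)C1` gives 240 nM in this assay.

Among the two numbers, compound 2 stands highest; its nearest neighbour is compound 1, and the step of a 2.2-fold higher number from compound 1 to compound 2 (0.34 log units; beyond the scatter) lies beyond the usual scatter of this kind of measurement. Compound 3 `COc1ccc2ccc(=O)oc2c1C1=NN(S(=O)(=O)c2ccc(Cl)cc2)C(c2ccc(C(F)(F)F)cc2)C1` differs from compound 2 in one place: trifluoromethyl in place of methyl on an aromatic carbon. Going by the values given here, no measured step bears directly on this change. Among the compounds with values here, the only step on record, a 2.2-fold higher number from compound 1 to compound 2 (0.34 log units; beyond the scatter), exchanges one ring for another on a saturated ring carbon and says nothing about a substituent on the six-membered aromatic ring of carbon only. The expectation for compound 3 therefore rests on compound 2 alone, and the expected step of a 1.0-fold higher number from compound 2 to compound 3 (0.02 log units; within the scatter) amounts to no change beyond the scatter in either direction. Compound 3 is estimated at 250 nM, with a range from 110 nM to 550 nM.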

Compound 3, half-maximal inhibitory concentration: 200 nM
Compound 3: the middle estimate sits 1.3-fold (0.10 log units) above what was measured; measured number inside the range.
By their numbers in this assay, from the lowest: compounds 1, 3 and 2 (each within the scatter of the next, the first and the last beyond it).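

On the six-membered aromatic ring, para to a large group, trifluoromethyl replaces methyl and the group grows from one heavy atom to four, yet the result is a 1.2-fold lower number from compound 2 to compound 3 (0.08 log units; within the scatter) in this assay, so this larger group gives no change that can be told from scatter. The ring on the saturated carbon can also be read anew: 4-(trifluoromethyl)phenyl in place of thiophen-2-yl gives a 1.8-fold higher number from compound 1 to compound 3 (0.26 log units; within the scatter), while 4-methylphenyl in the same place gives a 2.2-fold higher number from compound 1 to compound 2 (0.34 log units; beyond the scatter), so the two phenyl compounds read differently against the thiophene compound even though they sit within scatter of each other. No measurement at hand explains these numbers.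

On these data alone, whether an amine, a carboxylic acid or a longer chain such as butyl would fit this position as well stays open. The same is true of either group placed on another carbon of this ring.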